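Ester growth and tolerated concentration in a quinolinone series

The source may report more compounds than this note shows. Statements on the series, on what has been measured and on what is new or still open speak of the compounds shown alone.

Of the compounds shown here, three built on one shared core have been measured in an ADME assay on HepG2 2.2.15 cells (Homo sapiens) for cytotoxicity; a lower number here means that less compound is tolerated, a higher number that more compound is tolerated. Compound 1, `O=c1[nH]c2ccc(Cl)cc2c(-c2ccccc2Cl)c1CCO`, gives 380000 nM. Compound 2, `O=CCc1c(-c2ccccc2Cl)c2cc(Cl)ccc2[nH]c1=O`, gives 120000 nM. Compound 3, `O=C(OCCc1c(-c2ccccc2Cl)c2cc(Cl)ccc2[nH]c1=O)c1ccccc1`, gives 43000 nM, the lowest of the three numbers; its nearest neighbour is compound 2, and compound 1 lies furthest away. Each move toward a larger attachment on the chain has lowered the tolerated concentration: a 3.2-fold lower number from compound 1 to compound 2 (0.50 log units; beyond the scatter), an 8.8-fold lower number from compound 1 to compound 3 (0.95 log units; beyond the scatter) and a 2.8-fold lower number from compound 2 to compound 3 (0.45 log units; beyond the scatter).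

Compound 4, `COc1ccc(/C=C/C(=O)OCCc2c(-c3ccccc3Cl)c3cc(Cl)ccc3[nH]c2=O)cc1OC`, takes the next step from compound 3: 2-(3,4-dimethoxyphenyl)ethenyl in place of phenyl on a carbonyl carbon. The two steps that end at compound 3 both bear on it, since both add to the same chain, and both were modest and beyond the scatter. Within the data shown here, a further modest lowering in this assay is therefore expected, though no measured step covers an ethenyl or dimethoxy group, so the size is uncertain. Compound 4 is expected to give about 20000 nM, within 8000 nM to 50000 nM. That estimate means a step of a 2.2-fold lower number from compound 3 to compound 4 (0.33 log units; beyond the scatter).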

Compound 4, half-maximal cytotoxic concentration: > 1200000 nM
Compound 4: no number, only a limit; the forecaster's own chance of this, stated with the estimate: 10%; middle value at least 60-fold (1.77 log units) away from the limit.
By their numbers in this assay, from the lowest: compound 3; then compound 2; then compound 1. At a limit, above all of these: compound 4.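

On the carbonyl carbon, replacing phenyl with 2-(3,4-dimethoxyphenyl)ethenyl gives an at least 27-fold higher number from compound 3 to compound 4 (1.44 log units; beyond the scatter), a large step in the opposite direction to the earlier ones. A larger attachment on the chain therefore does not always go with a lower number in this assay: compound 1, compound 2 and compound 3 follow that trend, while compound 4 goes against it. Compound 4 has only a limit rather than a number, so the step has a known minimum but no known full size: the limit of > 1200000 nM in this assay, at which 1 of the 4 values shown sits.

The step brings in the ethenyl link and the two methoxy groups together, so the compounds shown leave open whether either alone, or only the pair, produces this rise. Going by these compounds, it also remains open how an amine or a carboxylic acid in place of the dimethoxyphenyl ring would read in this assay.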